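Series notes: from compound 2 to compound 4

The source may report more compounds than this note shows. Statements on the series, on what has been measured and on what is new or still open speak of the compounds shown alone.

The read-out throughout is a functional assay on the whole organism with Mus musculus as the target, in the maximal electroshock model, at a dose of 50 mg/kg by the oral route; on this read-out higher numbers stand for more inhibition at the one dose given (going by the name of the read-out) and lower numbers for less inhibition. Compound 1 `CN(C)CCCCOc1ccccc1/C=C/c1ccc(Cl)cc1` gives 0% in this assay. Compound 2 `CCCN(CCC)CCCCOc1ccccc1/C=C/c1ccccc1` gives 0%. Compound 3 `CN(C)CCCCOc1cccc(/C=C/c2ccccc2)c1` gives 0%. All three values stand level at the digits shown: compound 2 lies within the scatter of compound 1, its nearest neighbour on the numbers, and equally within the scatter of compound 3, the furthest. No pair of these compounds differs in only one place, so no single step between measured compounds can be read off; the three values together show no inhibition at the dose given.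

Compound 4 `CCCN1CCN(CCCCOc2ccccc2/C=C/c2ccccc2)CC1` has not yet been measured. Relative to compound 2 the change is 4-propylpiperazin-1-yl in place of dipropylamino on a saturated chain carbon, four bonds along the chain from an oxygen on an aromatic ring. Within the data shown here, no measured step speaks to this change. With compound 2 at 0% and no measured neighbour rising above the scatter, the step expected is a number 5 percentage points higher from compound 2 to compound 4 (within the scatter), that is, none beyond the scatter. Compound 4 is therefore estimated at 5% in this assay. For compound 4 the expected range runs from 0% to 30%. Compound 1, compound 2 and compound 3 all give readings at the bottom of the scale, and nothing in them points elsewhere for compound 4.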

Compound 4, a percentage reported as inhibition, in the whole organism at one dose (the size of the read-out at that dose, not a potency): 42.9%
The estimate for compound 4 lay 37.9 percentage points below the measured number; measured number above the stated range.
By their numbers in this assay, from the lowest: compounds 1, 2 and 3 (each within the scatter of the next); then compound 4.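

In this assay, among these compounds, 4-propylpiperazin-1-yl in place of dipropylamino on a saturated chain carbon, four bonds along the chain from an oxygen on an aromatic ring, gives a number 42.9 percentage points higher from compound 2 to compound 4 (beyond the scatter), the only step so far. Among the compounds shown here, this position is therefore not silent: the group held there can separate a reading at the bottom of the scale from a clear inhibition at the one dose, something the earlier compounds, level with one another and joined by no step, could not show. The change swaps an open-chain amine for a six-membered non-aromatic ring carrying a second nitrogen, and nothing at hand bears on why the reading moves or on which part of the new group goes with the step.

Open, going by these compounds, is whether piperidin-1-yl, morpholin-4-yl or 4-methylpiperazin-1-yl at the same place would keep the reading, which would separate the part played by the ring, by the second ring nitrogen and by the propyl group on it. Also open, on these data alone, is whether 4-propylpiperazin-1-yl has the same effect with a chloro group on the far aromatic ring, as in compound 1, and how the reading behaves at other doses.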